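This account rests on a few compounds, and the source may have more. Where it says the series, first, only, none or still open, it means among the compounds named here.

Of the compounds shown here, three have so far been measured in a functional assay on MIA PaCa-2 cells (Homo sapiens) for inhibition, read by MTT assay, with a stated time of 72 h; a higher number here means a weaker inhibitor of growth, a lower number a stronger inhibitor of growth. Compound 1 `O=S(=O)(NCCCNCc1ccc(Cl)c(Cl)c1)c1cc(C(F)(F)F)cc(C(F)(F)F)c1` gives 2700 nM, the lowest of the three numbers. Compound 2 `O=S(=O)(NCCCCCCNCc1ccc(Br)cc1)c1ccccc1F` gives 13300 nM in this assay. Compound 3 `CC(C)c1ccc(S(=O)(=O)NCCCCCCNCc2ccc(Br)cc2)cc1` gives 5730 nM. Compound 1 stands lowest, with compound 3 nearest and compound 2 furthest, both gaps beyond the scatter. Among the compounds with values here, the only single-point step among the measured compounds is a 2.3-fold lower number from compound 2 to compound 3 (0.37 log units; beyond the scatter), a change on the sulfonyl sulfur, far from the benzylamine end of the shared core.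

Compound 4 `O=S(=O)(NCCCNCc1cccc(Cl)c1)c1cc(C(F)(F)F)cc(C(F)(F)F)c1` has not yet been measured. It differs from compound 1 in one place: hydrogen in place of chloro on an aromatic carbon. No measured pair shares this change, so the removal of a chloro from the benzyl ring has no recorded step among these compounds. Within the data shown here, the one step that is recorded, on the sulfonyl sulfur, was modest, and it concerns a different part of the molecule. The author therefore expects that compound 4 moves only a little from compound 1, most likely toward a somewhat higher number, as a 1.5-fold higher number from compound 1 to compound 4 (0.17 log units; within the scatter), a step that may well fall within the scatter. Compound 4 is estimated at 4000 nM in this assay, with an expected range from 1500 nM to 11000 nM.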

Compound 4, concentration for 50% growth inhibition: 4400 nM
Compound 4: the middle estimate sits 1.1-fold (0.04 log units) below what was measured, and the stated range covers the measured number.
By their numbers in this assay, from the lowest: compounds 1, 4 and 3 (each within the scatter of the next, the first and the last beyond it); then compound 2.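

Within the data shown here, the swap of 3,4-dichlorobenzyl to 3-chlorobenzyl gives the first reading at the benzyl ring, where the earlier step reported only on the group at the sulfonyl sulfur. In this assay this replacement of chloro by hydrogen, at a place para to a large group and ortho to a chloro group, gives a 1.6-fold higher number from compound 1 to compound 4 (0.21 log units; within the scatter), which lies within the scatter, so the two compounds cannot be told apart and this single chloro shows no effect on growth inhibition that can be separated from repeat variation. Nothing at hand explains the size of this step.

The compounds shown leave open whether the remaining chloro on the benzyl ring can also be replaced by hydrogen, and whether a bromo, a methoxy or a nitrile at the position now carrying hydrogen would give a step beyond the scatter. Among these compounds, they also leave open whether removing this chloro would read the same on a core with a longer chain, since only the one pair carries this change.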